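This account rests on a few compounds, and the source may have more. Where it says the series, first, only, none or still open, it means among the compounds named here.

Of the compounds shown here, three have been measured in an ADME assay on microsomes from liver (Mus musculus) for metabolic stability, read by LC-MS, with a stated time of 10 min; a lower number here means that less of the compound is left, a higher number that more of the compound is left. Compound 1 `CN(C[C@@H]1Cc2c(cccc2N2CCNCC2)CN1)[C@H]1CCCc2cccnc21` gives 54.6%, compound 3 `CC(C)N(C[C@H]1Cc2c(cccc2N2CCNCC2)CN1)[C@H]1CCCc2cccnc21` gives 91%, and compound 2 `CC(C)N1CCN(c2cccc3c2C[C@H](CN(C)[C@H]2CCCc4cccnc42)NC3)CC1` gives 15.1%. Compound 2 therefore stands lowest of the three, beyond the usual scatter from both of the others.

Compound 4 `CN1CCN(c2cccc3c2C[C@H](CN(C)[C@H]2CCCc4cccnc42)NC3)CC1` has not yet been measured. It differs from compound 2 in one place: methyl in place of isopropyl on an amine nitrogen in a ring.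

Going by the values given here, no two measured compounds differ in only one place, so the data offer no direct guide to this change. The nearest clue is weak: compound 1 has no group on that nitrogen and differs from compound 2 elsewhere as well, and compound 1 gives 54.6%. On that basis, a modest rise is expected, with an estimated a number 11.9 percentage points higher from compound 2 to compound 4 (beyond the scatter), only a little beyond the scatter. For compound 4 the estimated value is 27%, with an expected range of 12% to 50%.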

Compound 4, percent of the compound remaining: 17%
The estimate for compound 4 lay 10 percentage points above the measured number; the range from low to high includes it.
By their numbers in this assay, from the lowest: compounds 2 and 4 (each within the scatter of the next); then compound 1; then compound 3.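

Going by these compounds alone, compound 2 and compound 4 are the first pair here to differ in one place only, so this change can now be read directly. Going from 4-isopropylpiperazin-1-yl to 4-methylpiperazin-1-yl gives a number 1.9 percentage points higher from compound 2 to compound 4 (within the scatter) in this assay, so on this ring nitrogen and with this core, the read-out does not tell the two groups apart. Nothing available explains this result or shows what happens to either compound in the microsomes.

Within the data shown here, only two groups have been compared at this position on this core, so it remains open whether a different one, such as ethyl, cyclopropyl or acetyl, would also leave the number within the scatter. Going by these compounds, it is also open whether swapping isopropyl for methyl would read the same way on the core of compound 3 .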